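Swapping a Pyrrolidine Urea for a Morpholine Urea

The source may hold more compounds than are shown below. What is called first, only, known or untested is meant among the compounds shown, and "the series" means these compounds.

Measured compounds:
Compound 1, `Cc1ccc(S(=O)(=O)Nc2cccc(-c3nc(-c4ccc(NC(=O)c5cccnc5)cc4Cl)no3)c2)cc1`: > 10000 nM
Compound 2, `O=C(Nc1ccc(-c2noc(-c3cccc(NS(=O)(=O)c4ccc(NC(=O)N5CCCC5)cc4)c3)n2)c(Cl)c1)c1cccnc1`: 5800 nM

Of the compounds shown here, two built on a shared core have been tested in a functional assay on MDA-MB-231 cells (Homo sapiens) for antiproliferative activity, read by MTT assay, with a stated time of 72 h; a lower number here means a stronger inhibitor, a higher number a weaker inhibitor. Compound 1 sits at the limit of the assay, > 10000 nM, which is a limit and not a number; the set therefore has one value at the limit of > 10000 nM in this assay, at which 1 of the 2 values shown sits. Among the compounds with values here, compound 2 gives 5800 nM, the only true number in this assay so far, so compound 2 stands as the sole fixed point in the set. Within the data shown here, the single measured step, an at least 1.7-fold lower number from compound 1 to compound 2 (0.23 log units; that floor lies within the scatter), concerns a change at a different position and cannot be read as more than a loose reference.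

Compound 3, `O=C(Nc1ccc(-c2noc(-c3cccc(NS(=O)(=O)c4ccc(NC(=O)N5CCOCC5)cc4)c3)n2)c(Cl)c1)c1cccnc1`, differs from compound 2 by morpholin-4-yl in place of pyrrolidin-1-yl on a carbonyl carbon. Among the measured compounds shown here, no measured step speaks to this change, and the one step that exists in this assay offers no direct guide. Given that, compound 3 is expected to show a step of a 1.1-fold higher number from compound 2 to compound 3 (0.05 log units; within the scatter) from compound 2, that is, none clearly beyond the scatter. The estimate for compound 3 in this assay is 6500 nM, with a range from 2500 nM to 16000 nM.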

Compound 3, half-maximal inhibitory concentration: > 10000 nM
Compound 3: a limit, no number; the forecaster's own chance of this, stated with the estimate: 30%; at least 1.5-fold (0.18 log units) between middle value and limit.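

Within the data shown here, compound 3 gives the first direct reading of this position in this assay: with morpholin-4-yl in place of pyrrolidin-1-yl on the carbonyl carbon, the step is an at least 1.7-fold higher number from compound 2 to compound 3 (0.23 log units; that floor lies within the scatter). Going by these compounds, the added ring oxygen therefore brings no measurable gain over compound 2, but the result does not establish a real loss either, and the true size of the change remains unknown. Among these compounds, the step between compound 1 and compound 3 cannot be read, so compound 2 remains the only compound with a true number, and the set now leans heavily on a single limit: the limit of > 10000 nM in this assay, at which 2 of the 3 values shown sit.

The compounds shown leave open how far the true value of compound 3 lies from that limit, and therefore whether the swap matters at all. They also leave open whether a piperidin-1-yl ring, an open-chain dimethylamino group or a 4-methylpiperazin-1-yl ring on the same carbonyl carbon would give a clearly lower number than compound 2 or would also end at the limit.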